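Cyano in place of chloro on the aryl: expected channel activation

The source may report more compounds than this note shows. Statements on the series, on what has been measured and on what is new or still open speak of the compounds shown alone.

Measured so far:
compound 1 `CCC(C)n1nc(C)cc1NC(=O)Cn1nnc(-c2ccccc2)n1`: > 5000 nM
compound 2 `Cc1cc(NC(=O)Cn2nnc(-c3cccc(Cl)c3)n2)n(C2CCCCC2)n1`: 300 nM

Among the measured compounds shown here, in an assay on HEK293 cells for activation of Kir3.1/Kir3.2 (Homo sapiens), read by thallium flux (on this read-out higher numbers stand for an effect only at larger amounts of compound and lower numbers for an effect already at smaller amounts), compound 2 gives 300 nM, the only number in the set. Compound 1 sits at the limit of > 5000 nM in this assay, at which 1 of the 2 values shown sits, in this assay, so its value is a limit, not a number. For the measured compounds named here, no step between measured compounds that differ in one place is available, so the size of a single change has not yet been seen.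

Compound 3 `Cc1cc(NC(=O)Cn2nnc(-c3cccc(C#N)c3)n2)n(C2CCCCC2)n1` differs from compound 2 by cyano in place of chloro on an aromatic carbon. Cut one bond further out, the change reads 3-chlorophenyl to 3-cyanophenyl. Going by the values given here, with no measured step on this change to lean on, the expected step is a 1.8-fold higher number from compound 2 to compound 3 (0.26 log units; within the scatter), small and toward an effect only at larger amounts, likely within the scatter. Compound 3 is estimated at 550 nM in this assay, with a range from 200 nM to 2000 nM.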

Compound 3, half-maximal effective concentration: 183 nM
Compound 3: middle estimate off by 3.0-fold (0.48 log units), on the high side; measured number below the stated range.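

In this assay, replacing chloro with cyano on the aromatic carbon gives a 1.6-fold lower number from compound 2 to compound 3 (0.21 log units; within the scatter), so this change does not separate the two groups at this position. Among the compounds shown here, this is the first single-place step, and it shows that 3-cyanophenyl can stand in for 3-chlorophenyl, with a hydrogen-bond acceptor entering, without the read-out moving beyond the scatter. No measured property shown here bears on this step.

For the compounds shown here, compound 1 gives > 5000 nM, which is a limit of the assay and not a number, and it differs from the other compounds in more than one place, so it yields no step. Still open, from the compounds shown here alone, is how the read-out responds when an amine, a carboxylic acid or a methoxy group occupies this aromatic carbon.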